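Replacing the oxazolyl amine substituent with a thienylmethyl group

This account rests on a few compounds, and the source may have more. Where it says the series, first, only, none or still open, it means among the compounds named here.

Compound 3 `Cc1nc(Nc2ncco2)nc(N[C@@H]2C[C@H](CO)[C@@H](O)[C@H]2O)c1-c1nc2ccccc2s1` is measured only as a limit in an ADME assay on cells (Homo sapiens) for cytotoxicity, read by polymerase chain reaction, with a stated time of 3 days; on this read-out higher numbers stand for lower toxicity in this test and lower numbers for higher toxicity in this test: compound 3 gives > 25000 nM, a limit of the assay rather than a number. Compound 2 `Cc1nc(NCCNS(C)(=O)=O)nc(N[C@@H]2C[C@H](CO)[C@@H](O)[C@H]2O)c1-c1nc2ccccc2s1` likewise sits at a limit in this assay, where compound 2 gives > 25000 nM. Compound 1 `Cc1nc(N)nc(N[C@@H]2C[C@H](CO)[C@@H](O)[C@H]2O)c1-c1nc2ccccc2s1`, bearing hydrogen on the same nitrogen, gives 4000 nM in this assay. Both an at least 6.2-fold higher number from compound 1 to compound 2 (0.79 log units; beyond the scatter) and an at least 6.2-fold higher number from compound 1 to compound 3 (0.79 log units; beyond the scatter) move upward, while a step that the two limits leave unreadable from compound 2 to compound 3 stays unreadable because of the limit of > 25000 nM in this assay, at which 2 of the 3 values shown sit. Compound 4 `Cc1nc(NCc2ccsc2)nc(N[C@@H]2C[C@H](CO)[C@@H](O)[C@H]2O)c1-c1nc2ccccc2s1` differs from compound 3 by (thiophen-3-yl)methyl in place of 1,3-oxazol-2-yl on a nitrogen on an aromatic ring. Given that compound 2 and compound 3 both stand at the limit of > 25000 nM in this assay, at which 2 of the 3 values shown sit, a step of an at least 1.2-fold lower number from compound 3 to compound 4 (0.09 log units; that floor lies within the scatter) is expected, keeping compound 4 near the limit. Compound 4 is therefore estimated at 20000 nM in this assay, with a range from 6000 nM to 50000 nM.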

Compound 4, half-maximal cytotoxic concentration: 6000 nM
Compound 4: middle estimate off by 3.3-fold (0.52 log units), on the high side; low and high end bracket the measured number.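

In this assay, a substituent on this nitrogen does not by itself keep the number at the limit: (thiophen-3-yl)methyl gives an at least 4.1-fold lower number from compound 3 to compound 4 (0.61 log units; beyond the scatter) and an at least 4.1-fold lower number from compound 2 to compound 4 (0.61 log units; beyond the scatter). It also gives a 1.5-fold higher number from compound 1 to compound 4 (0.18 log units; within the scatter), so this group leaves the number level with that of the unsubstituted amine, unlike the substituents of compound 2 and compound 3.

The compounds shown leave open whether the thiophene ring or the saturated chain carbon accounts for this; benzyl or (1,3-oxazol-2-yl)methyl on this nitrogen would separate the two. How far compound 2 and compound 3 differ stays unreadable because both are limits: the limit of > 25000 nM in this assay, at which 2 of the 4 values shown sit.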